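The compounds below may be only part of what the source reports. "The series", "measured", "known", "first", "only" and "open" are said of these compounds alone.

In a functional assay on HT-29 cells (Homo sapiens) for cytotoxicity, read by MTT assay, with a stated time of 72 h (on this read-out lower numbers stand for stronger inhibition and higher numbers for weaker inhibition), three compounds share a core and differ in the group carried on a nitrogen. Compound 1 `Fc1cc(Nc2cc(Nc3ccc(Cl)cc3)ncn2)ccc1Oc1ccncc1-c1cccnc1` gives 980 nM, and compound 2 `COc1cc(Nc2cc(Nc3ccc(Oc4ccncc4-c4cccnc4)c(F)c3)ncn2)cc(OC)c1` gives 1130 nM; the change a 1.2-fold higher number from compound 1 to compound 2 (0.06 log units; within the scatter) shows that swapping one aryl group for another on a nitrogen left the read-out essentially unchanged. Compound 3 `Cn1c(=O)c(C(=O)Nc2ccc(Oc3ccncc3-c3cccnc3)c(F)c2)nn(-c2ccc(Cl)cc2)c1=O` gives 440 nM, the lowest of the three numbers, standing beyond the scatter from both compound 1 and compound 2.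

Compound 4 `Cn1c(=O)c(C(=O)Nc2ccc(Oc3ccncc3-c3cccnc3)c(F)c2)nn(-c2ccc(F)c(Cl)c2)c1=O` is the next step. Relative to compound 3 the difference is 3-chloro-4-fluorophenyl in place of 4-chlorophenyl on an aromatic nitrogen. Among the compounds with values here, the only measured step that bears on this kind of change is the one from compound 1 to compound 2, which was within the scatter, so no step beyond the scatter is expected in this assay. For compound 4 the estimated change is a 1.0-fold lower number from compound 3 to compound 4 (0.02 log units; within the scatter), and compound 4 is expected to give 420 nM, with a likely range from 200 nM to 900 nM.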

Compound 4, half-maximal inhibitory concentration: 4780 nM
Beside the measured number, compound 4's estimate is 11-fold (1.06 log units) below it; measured number above the stated range.
By their numbers in this assay, from the lowest: compound 3; then compounds 1 and 2 (each within the scatter of the next); then compound 4.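

In this assay, the group on the aromatic nitrogen of the core of compound 3 proves sensitive to a small change: an 11-fold higher number from compound 3 to compound 4 (1.04 log units; beyond the scatter) comes with a move from 7 to 8 heavy atoms, with no change in hydrogen-bond donors, hydrogen-bond acceptors or net charge. The earlier aryl swap on a nitrogen, a 1.2-fold higher number from compound 1 to compound 2 (0.06 log units; within the scatter), belonged to a different core and gave no sign of such a large step, so it did not carry over to this position. Nothing available here accounts for the size of this step.

The compounds shown do not separate the added fluorine from the changed place of the chlorine, which a 3-chlorophenyl or a 4-fluorophenyl on this nitrogen would do. As far as these compounds go, how a benzyl group or a simple unsubstituted phenyl would read at this position also stays open.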